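A few compounds are considered here, and "the series" means these few. Any claim that something is new, unique, unknown or untested is made for them only; others in the source may bear on it.

Compound 1 `COc1cc(NCc2ccc(C)o2)ccc1-c1cnco1`: 63400 nM
Compound 2 `COc1cc(NCc2ccc(C)s2)ccc1-c1cnco1`: 34400 nM

Among the measured compounds shown here, in an ADME assay on Huh-7 cells (Homo sapiens) for cytotoxicity, read by MTT assay, with a stated time of 96 h (on this read-out lower numbers stand for higher toxicity in this test and higher numbers for lower toxicity in this test), compound 2 gives 34400 nM, which lies within the scatter of the only other measured compound, compound 1 at 63400 nM. Compound 3 `COc1cc(NCc2scnc2C)ccc1-c1cnco1` has 4-methyl-1,3-thiazol-5-yl in place of 5-methylthiophen-2-yl on a saturated chain carbon bound to a nitrogen on an aromatic ring. For the measured compounds named here, the one measured step, a 1.8-fold lower number from compound 1 to compound 2 (0.27 log units; within the scatter), exchanged the group at this same place and stayed within the scatter, so no step beyond the scatter is expected here. The expected step is a 1.2-fold higher number from compound 2 to compound 3 (0.07 log units; within the scatter). For compound 3 the estimate is 40000 nM, with an expected range of 15000 nM to 95000 nM.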

Compound 3, half-maximal cytotoxic concentration: 58500 nM
The estimate for compound 3 lay 1.5-fold (0.17 log units) below the measured number; measured number inside the range.
By their numbers in this assay, from the lowest: compounds 2, 3 and 1 (each within the scatter of the next).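

In this assay, 4-methyl-1,3-thiazol-5-yl in place of 5-methylthiophen-2-yl gives a 1.7-fold higher number from compound 2 to compound 3 (0.23 log units; within the scatter), and the same group in place of 5-methylfuran-2-yl gives a 1.1-fold lower number from compound 1 to compound 3 (0.03 log units; within the scatter). At this place, on a saturated chain carbon bound to a nitrogen on an aromatic ring, three five-membered aromatic rings, now including one with 2 hetero atoms, cannot be told apart in this test. Nothing measured here offers a cause for these small steps.

On these data alone, whether a phenyl ring, an amine or a carboxylic acid at this place would give a step beyond the scatter stays open.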